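Working notes before compound 3 is measured

The compounds below may be only part of what the source reports. "The series", "measured", "known", "first", "only" and "open" are said of these compounds alone.

Measured so far:
compound 1 `CC1=NN(S(=O)(=O)c2ccc(C)cc2)C(c2cc(Br)ccc2O)C1` — 30700 nM
compound 2 `O=C(c1ccccc1)N1N=C(c2cc3ccccc3oc2=O)CC1c1ccccc1` — 12700 nM

In a functional assay on MGC-803 cells (Homo sapiens) for cytotoxicity, read by MTT assay, with a stated time of 48 h (on this read-out higher numbers stand for weaker inhibition and lower numbers for stronger inhibition), compound 2 gives 12700 nM, the lower of the two numbers measured. Compound 1 gives 30700 nM in this assay, a higher number, and the gap between the two lies beyond the usual scatter. For the measured compounds named here, no pair of measured compounds differs in only one place, so no single structural step has a known size here.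

Compound 3 `NC(=O)C1CCN(CC(=O)N2N=C(c3cc4ccccc4oc3=O)CC2c2ccccc2)CC1` is the compound to be measured next. It differs from compound 2 in one place: (4-carbamoylpiperidin-1-yl)methyl in place of phenyl on a carbonyl carbon. Nothing measured in the series speaks to this change, and the carbonyl carbon that carries it keeps its other neighbour unchanged. The expectation for the step is none beyond the scatter, a 1.1-fold higher number from compound 2 to compound 3 (0.04 log units; within the scatter), in this assay. Compound 3 is accordingly estimated at 14000 nM in this assay, with a range from 5000 nM to 40000 nM.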

Compound 3, half-maximal inhibitory concentration: 21500 nM
Compound 3: middle estimate off by 1.5-fold (0.19 log units), on the low side; measured number inside the range.
By their numbers in this assay, from the lowest: compounds 2, 3 and 1 (each within the scatter of the next, the first and the last beyond it).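

For the compounds shown here, compound 2 and compound 3 form the first pair that differs in one place. On a carbonyl carbon whose other neighbour is an amide-type nitrogen in a ring, (4-carbamoylpiperidin-1-yl)methyl in place of phenyl gives, in this assay, a 1.7-fold higher number from compound 2 to compound 3 (0.23 log units; within the scatter), so this assay does not separate the two compounds even though the entering group swaps an aromatic ring of carbon only for a non-aromatic ring with a hetero atom and adds a hydrogen-bond donor and acceptors. Nothing measured explains this outcome or bears on how the position accepts such different groups.

One step cannot show which part of the entering group matters, or whether the position would respond to other groups. A carboxylic acid in place of the carbamoyl, a morpholine ring in place of the piperidine, or a longer chain before the ring would each test this further.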